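The compounds below may be only part of what the source reports. "The series", "measured", "known", "first", "only" and "open" are said of these compounds alone.

Measured in an in vivo ADME assay on the whole organism (plasma) for pharmacokinetics, with Canis familiaris (Canis lupus familiaris) as the target, at a dose of 1 mg/kg; a lower number here means slower removal, a higher number faster removal of the compound:
- Compound 1 `CC(C)(O)c1ccn2c(-c3ccc(F)c(-c4cccnc4)c3)cnc2n1`: 8.1 mL/min/kg
- Compound 2 `CC(C)(O)c1cnn2c(-c3ccc(F)c(-c4ncc(F)cc4F)c3)cnc2n1`: 0.5 mL/min/kg

Compound 2, at 0.5 mL/min/kg, holds the lower of the two numbers, and compound 1, at 8.1 mL/min/kg, lies above it by more than the usual scatter. Compound 3 `CC(C)(O)c1cnn2c(-c3ccc(F)c(-c4ncccc4C#N)c3)cnc2n1` keeps the structure of compound 2 except at one point: 3-cyanopyridin-2-yl stands in place of 3,5-difluoropyridin-2-yl on an aromatic carbon (3-cyanopyridin-2-yl in place of 3,5-difluoropyridin-2-yl on an aromatic carbon). Going by the values given here, no measured pair differs at this place alone, so the data do not show what this exchange does. Compound 2 already sits at the low end of the two values, and an upward move therefore seems more likely than a downward one. A moderate rise is expected in this assay, estimated as a 3.0-fold higher number from compound 2 to compound 3 (0.48 log units; beyond the scatter). For compound 3 the estimate is 1.5 mL/min/kg, with an expected range of 0.5 mL/min/kg to 5 mL/min/kg.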

Compound 3, clearance: 2.2 mL/min/kg
For compound 3 the middle estimate is 1.5-fold (0.17 log units) below the measured one, within the range that was stated.
By their numbers in this assay, from the lowest: compound 2; then compound 3; then compound 1.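

In this assay, placing 3-cyanopyridin-2-yl instead of 3,5-difluoropyridin-2-yl on this aromatic carbon, ortho to a fluoro group, gives a 4.4-fold higher number from compound 2 to compound 3 (0.64 log units; beyond the scatter). Going by these compounds alone, this is the first pair here that differs at this place alone, and it shows that the number responds to the group held at this point while the rest of the structure stays fixed. Nothing available accounts for the size or direction of this step, so it stands as an observation only.

The compounds shown do not separate the loss of the two fluoro groups from the arrival of the nitrile, and a pyridine ring carrying a chloro or methoxy group could bear on that. As far as these compounds go, whether the same exchange would give a similar step on the core of compound 1 also remains open.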